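A few compounds are considered here, and "the series" means these few. Any claim that something is new, unique, unknown or untested is made for them only; others in the source may bear on it.

Compound 2 `CN1CCN(CC(=O)Nc2ccc(-c3nc(-c4ccccc4)c(-c4ccccc4)n3C)cc2)CC1` carries a shared core with a methylpiperazine arm on the amide side. In a functional assay on MCF7 cells (Homo sapiens) for cytotoxicity, read by MTT assay, with a stated time of 24 h, tested at 6.4 ug/mL (on this read-out higher numbers stand for a stronger effect at the one concentration tested and lower numbers for a weaker effect), compound 2 gives 28.6%, the lower of the two numbers measured here. Among the measured compounds shown here, its nearest neighbour is compound 1 `Cc1nnc(SCC(=O)Nc2ccc(-c3nc(-c4ccccc4)c(-c4ccccc4)n3C)cc2)s1`, which in this assay gives 67.8%; the only measured step, a number 39.2 percentage points lower from compound 1 to compound 2 (beyond the scatter), swapped the whole arm on the saturated chain carbon bound to the carbonyl carbon. Compound 3 `Cn1c(-c2ccc(NC(=O)CN3CCN(Cc4ccccc4)CC3)cc2)nc(-c2ccccc2)c1-c1ccccc1` differs from compound 2 only by phenyl in place of hydrogen on a saturated chain carbon bound to an amine nitrogen in a ring. For the measured compounds named here, no measured step alters the outer end of the piperazine, so the one step known here does not bear directly on this change, and no basis exists for expecting a shift beyond the scatter. The estimate for compound 3 in this assay is 35%, within a range from 15% to 60%, which means an expected step of a number 6.4 percentage points higher from compound 2 to compound 3 (within the scatter).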

Compound 3, a percentage reported as activity, at one concentration (the size of the read-out at that concentration, not a potency): 23.8%
Estimate against measurement, compound 3: 11.2 percentage points above; low and high end bracket the measured number.
By their numbers in this assay, from the lowest: compounds 3 and 2 (each within the scatter of the next); then compound 1.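

Among the compounds shown here, the step in this assay, a number 4.8 percentage points lower from compound 2 to compound 3 (within the scatter), is the first look at the outer end of the piperazine arm, since the earlier step replaced the whole arm. It shows that changing methyl to benzyl, which adds a phenyl ring on a saturated chain carbon bound to an amine nitrogen in a ring, leaves the reading within the usual scatter. For these two compounds, then, this addition at the outer end makes no clear difference at the one concentration tested. Nothing given here speaks to the reason for this result.

This is a single change at a single place, so it cannot be said whether other groups would behave the same way. A carboxylic acid, a hydroxyethyl group or a longer chain ending in phenyl at this end remains an open case.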